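The source may hold more compounds than are shown below. What is called first, only, known or untested is meant among the compounds shown, and "the series" means these compounds.

Compound 3 `COc1cccc(S(=O)(=O)Nc2ccc3oc(-c4ccccc4)nc3c2)c1` carries a 3-methoxyphenyl on the sulfonyl sulfur of the shared core. In an assay on cells for inhibition of HSP60/HSP10 (Homo sapiens), with a stated time of 60 min (on this read-out higher numbers stand for weaker inhibition and lower numbers for stronger inhibition), compound 3 gives > 100000 nM, which is a limit of the assay and not a number. The other measured compounds are compound 1 `O=S(=O)(Nc1ccc2oc(-c3ccccc3)nc2c1)c1cccc(C(F)(F)F)c1` and compound 2 `O=S(=O)(Nc1ccc2oc(-c3ccccc3)nc2c1)c1ccc(F)c(C(F)(F)F)c1`. In this assay compound 1 gives > 100000 nM, again a limit. In this assay compound 2 gives 69000 nM. The step of an at least 1.4-fold lower number from compound 1 to compound 2 (0.16 log units; that floor lies within the scatter) is small, and the step that the two limits leave unreadable from compound 1 to compound 3 cannot be read because of the limit of > 100000 nM in this assay, at which 2 of the 3 values shown sit.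

Compound 4 `COc1ccccc1S(=O)(=O)Nc1ccc2oc(-c3ccccc3)nc2c1` differs from compound 3 only in that (2-methoxyphenyl in place of 3-methoxyphenyl on a sulfonyl sulfur). Going by the values given here, no measured step moves a methoxy to another place on that ring, so none bears directly on this change; the steps that exist, an at least 1.4-fold lower number from compound 1 to compound 2 (0.16 log units; that floor lies within the scatter) and a step that the two limits leave unreadable from compound 1 to compound 3, show only that every change made so far has left the numbers at the limit or close to it. The step that the limit leaves unreadable from compound 3 to compound 4 is therefore expected to stay within the scatter, with a high chance that only a limit is reported again. Compound 4 is estimated at 150000 nM in this assay, within 50000 nM to 500000 nM.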

Compound 4, half-maximal inhibitory concentration: > 100000 nM
Compound 4 was reported as a limit; the forecaster's own chance of this, stated with the estimate: 70%; the middle value lies beyond the limit too.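

In this assay compound 4 gives > 100000 nM, a limit of the assay and not a number. Going by these compounds alone, compound 3 gives > 100000 nM, again a limit, so no step between compound 3 and compound 4 can be read: the limit of > 100000 nM in this assay, at which 3 of the 4 values shown sit. The compounds shown leave open whether 2-methoxyphenyl and 3-methoxyphenyl on a sulfonyl sulfur differ at all in this assay.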